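Methoxy in Place of Fluoro: An Expected Maximal Response

A few compounds are considered here, and "the series" means these few. Any claim that something is new, unique, unknown or untested is made for them only; others in the source may bear on it.

Compound 1 `Cc1cc2c(cc1C(=O)c1ccc3cc(C(=O)O)ccc3c1)C(C)(C)CCC2(C)C` and compound 2 `CC1(C)CCC(C)(C)c2cc(C(=O)c3ccc4cc(C(=O)O)ccc4c3)c(F)cc21` share one core and differ only in a single group on an aromatic carbon. In an assay on isolated protein with retinoic acid receptor beta (Homo sapiens) as the target (on this read-out higher numbers stand for larger maximal responses and lower numbers for smaller maximal responses), compound 1 gives 81%, and compound 2 gives 81%. The step of no change at the digits printed from compound 1 to compound 2 (within the scatter) shows that fluoro in place of methyl on an aromatic carbon left the maximal response where it was. Compound 2 therefore stands level with compound 1 on the numbers shown, with nothing separating the two beyond the scatter.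

Compound 3 `COc1cc2c(cc1C(=O)c1ccc3cc(C(=O)O)ccc3c1)C(C)(C)CCC2(C)C` has not yet been measured. It differs from compound 2 in one place: methoxy in place of fluoro on an aromatic carbon. Among the measured compounds shown here, the only measured step that bears on this position is no change at the digits printed from compound 1 to compound 2 (within the scatter), and that step was no change within the scatter. On this basis the step of no change at the digits printed from compound 2 to compound 3 (within the scatter) is expected to lie within the scatter as well. The estimate for compound 3 in this assay is 81%, with a range from 70% to 92%.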

Compound 3, largest response reached (reported as maximum), in percent of the reference or control that the assay uses: 61%
Beside the measured number, compound 3's estimate is 20 percentage points above it; the measured number lies below the stated range.
By their numbers in this assay, from the lowest: compound 3; then compounds 1 and 2 (each within the scatter of the next).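

In this assay methoxy in place of fluoro on an aromatic carbon gave a number 20 percentage points lower from compound 2 to compound 3 (beyond the scatter) and methoxy in place of methyl at the same place gave a number 20 percentage points lower from compound 1 to compound 3 (beyond the scatter) in the same read-out, so both measured neighbours of compound 3 part from it by the same margin. Among the compounds shown here, the earlier exchange, which showed no change at the digits printed from compound 1 to compound 2 (within the scatter) as its only step, had suggested that this carbon, ortho to a large group, tolerated a change of substituent; the new result shows that this tolerance covers fluoro and methyl but does not extend to methoxy. Nothing measured here says what about the methoxy group lies behind the lower maximal response.

The compounds shown leave open whether a hydroxy group, an ethoxy group or a chlorine atom on this carbon would stay level with compound 1 and compound 2 or fall with compound 3. They also leave open whether an amine there would behave like methoxy, which would show whether the oxygen or the added carbon goes with the change.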